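Thiophene-substituted fused cores: the hydrogen-to-methyl step

This account rests on a few compounds, and the source may have more. Where it says the series, first, only, none or still open, it means among the compounds named here.

Of the compounds shown here, three have been measured in a functional assay on cells (Cancer cell lines, Homo sapiens) for inhibition; on this read-out higher numbers stand for weaker inhibition of growth and lower numbers for stronger inhibition of growth. Compound 1 `Cc1cc(-c2nc3n(c2/C=N/NC(=N)N)CCS3)c(C)s1` gives 15500 nM. Compound 2 `N=C(N)N/N=C/c1c(-c2ccsc2)nc2sccn12` gives 14800 nM. Compound 3 `CCOC(=O)c1nc2sc(Cl)cn2c1/C=N\NC(=N)N` gives 17000 nM. Compound 2 is not separated from compound 1 or from compound 3 by more than the usual scatter of repeated measurements, so the three numbers describe one common level rather than a gradation.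

The next compound is compound 4 `Cc1cn2c(/C=N/NC(=N)N)c(-c3ccsc3)nc2s1`, which differs from compound 2 only by methyl in place of hydrogen on an aromatic carbon. Among the measured compounds shown here, no step between two measured compounds of this kind is available, and no other pair here isolates a methyl on that ring. With the measured trio sitting together, nothing in the numbers points to either direction for this change. The step from compound 2 to compound 4 is therefore expected to be small, a 1.1-fold lower number from compound 2 to compound 4 (0.02 log units; within the scatter), with no movement beyond the scatter foreseen. On this basis compound 4 is estimated at 14000 nM in this assay, within a range from 6000 nM to 32000 nM.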

Compound 4, concentration for 50% growth inhibition: 7590 nM
Beside the measured number, compound 4's estimate is 1.8-fold (0.27 log units) above it; measured number inside the range.
By their numbers in this assay, from the lowest: compounds 4, 2, 1 and 3 (each within the scatter of the next, the first and the last beyond it).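

Among the compounds shown here, this is the first direct reading of the aromatic carbon next to the ring sulfur: replacing hydrogen with methyl there gives a 1.9-fold lower number from compound 2 to compound 4 (0.29 log units; within the scatter) in this assay. The step stays within the scatter, so this position accepts a methyl without a loss of growth inhibition beyond the scatter, and no gain can be claimed from this single pair. No measurement available here bears on the size of this step.

The compounds shown leave open how a longer chain such as ethyl, or an amine or a carboxylic acid, would read on this same carbon. Going by these compounds, it also remains open whether the hydrogen-to-methyl step would read the same with a group other than the thiophene on the shared core.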